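Chlorophenyl position swap carried across two cores

The source may report more compounds than this note shows. Statements on the series, on what has been measured and on what is new or still open speak of the compounds shown alone.

Measured in a functional assay on NCI-H460 cells (Homo sapiens) for cytotoxicity, read by MTT assay, with a stated time of 72 h; on this read-out higher numbers stand for weaker inhibition and lower numbers for stronger inhibition:
compound 1 `CN(C)CCNc1nc(-c2ccc(NC(=O)Nc3ccc(Cl)cc3)cc2)nc2ccsc12` gives 130 nM
compound 2 `CN(C)CCNc1nc(-c2ccc(NC(=O)Nc3ccccc3Cl)cc2)nc2ccsc12` gives 230 nM
compound 3 `CCN(CC)CCCNc1nc(-c2ccc(NC(=O)Nc3ccc(Cl)cc3)cc2)nc2c(Cl)c(Cl)sc12` gives 270 nM

On the core of compound 1 the change 2-chlorophenyl in place of 4-chlorophenyl on an amide-type nitrogen gave a 1.8-fold higher number from compound 1 to compound 2 (0.25 log units; within the scatter). Compound 4 `CCN(CC)CCCNc1nc(-c2ccc(NC(=O)Nc3ccccc3Cl)cc2)nc2c(Cl)c(Cl)sc12` carries the same kind of change on the core of compound 3, (2-chlorophenyl in place of 4-chlorophenyl on an amide-type nitrogen), and the place of the change is the same in words. The difference between the two cores is not broken down here. For compound 4 the step of a 1.6-fold higher number from compound 3 to compound 4 (0.19 log units; within the scatter) is expected, about the size of the earlier one. This rests on a single earlier pair, whose step a 1.8-fold higher number from compound 1 to compound 2 (0.25 log units; within the scatter) stayed within the scatter, and on compound 3 standing at 270 nM. Compound 4 is thus estimated at 420 nM in this assay, with 200 nM to 900 nM as the expected range.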

Compound 4, half-maximal inhibitory concentration: 330 nM
Compound 4: the middle estimate sits 1.3-fold (0.10 log units) above what was measured; the measured number falls inside the stated range.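

In this assay, 2-chlorophenyl in place of 4-chlorophenyl on the amide-type nitrogen gave a 1.2-fold higher number from compound 3 to compound 4 (0.09 log units; within the scatter), so this step is also small on the second core. The change behaves alike on both cores: the same change on two cores in this assay, a 1.8-fold higher number (0.25 log units; within the scatter) from compound 1 to compound 2 and a 1.2-fold higher number (0.09 log units; within the scatter) from compound 3 to compound 4, 1.4-fold (0.16 log units) apart, within the scatter of two such steps. This shows no dependence on the core across these two pairs, but with both steps within the scatter it does not separate 2-chlorophenyl from 4-chlorophenyl, and two pairs set no general rule for the series.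

The compounds shown leave open whether a plain phenyl or a methoxyphenyl on the same nitrogen would give a clearer step. Also open, on these data alone, is whether the swap behaves alike on a compound with a morpholine in the side chain.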